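Compound 2 to compound 4: hydroxy to methoxy

The source may report more compounds than this note shows. Statements on the series, on what has been measured and on what is new or still open speak of the compounds shown alone.

In a functional assay on A549 cells (Homo sapiens) for cytotoxicity, read by MTT assay, with a stated time of 24 h (on this read-out lower numbers stand for stronger inhibition and higher numbers for weaker inhibition), compound 2 (`CC(C)c1cc2c(cc1O)[C@]13CCC[C@](C)(CO[C@H]1O)[C@@H]3CC2`) gives > 10000 nM as a limit and not as a number. Compound 3 (`CC(C)c1cc2c(cc1O)[C@]13CCC[C@](C)(CO[C@@H]1O)[C@@H]3CC2`) gives > 10000 nM as a limit too. Compound 1 (`CC(C)C1=C[C@]2(O)CC[C@H]3[C@]4(C)CCC[C@]3(C(=O)OC4)C2=CC1=O`) gives > 10000 nM as a limit too. The standing of compound 2 is thus the limit of > 10000 nM in this assay, at which 3 of the 3 values shown sit, and nothing more.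

The change to compound 4 (`CO[C@@H]1OC[C@@]2(C)CCC[C@@]13c1cc(O)c(C(C)C)cc1CC[C@@H]23`) is methyl in place of hydrogen on an oxygen on a saturated carbon and reads as hydroxy to methoxy: methyl in place of hydrogen on an oxygen on a saturated carbon. Within the data shown here, the only measured step is a step that the two limits leave unreadable from compound 2 to compound 3 and it concerns the fact that compounds 2 and 3 differ only in the configuration as drawn so it gives no size to carry over. Among the measured compounds shown here, no measured step replaces that hydrogen. With compound 2 at a limit and no readable step, no direction can be argued, so no step beyond the scatter is expected in this assay here. The expected size is a step that the limit leaves unreadable from compound 2 to compound 4 and it is an estimate resting on limits alone. Compound 4 is estimated at 20000 nM with an expected range from 8000 nM to 50000 nM and a report as a limit is the likeliest outcome.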

Compound 4, half-maximal inhibitory concentration: > 10000 nM
Compound 4 ended at the assay's limit (the forecaster's own chance of this, stated with the estimate: 85%); the middle value is on the limit's open side.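

In this assay compound 4 gives > 10000 nM, a limit and not a number. Among these compounds, compound 2 also sits at a limit, so no step from compound 2 to compound 4 can be read. The compounds shown leave open whether methyl in place of hydrogen changes cytotoxicity at all, and whether any compound in the series gives a measurable value in this assay.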